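Chain length series on the shared core

The compounds below may be only part of what the source reports. "The series", "measured", "known", "first", "only" and "open" are said of these compounds alone.

Three compounds share one core and differ only in the length of the saturated chain that follows the amide-type nitrogen: compound 1 `CN(C)C(=O)c1cc2cnc(Nc3ccc(C(=O)NCCCN=C=S)cc3)nc2n1C1CCCC1`, compound 2 `CN(C)C(=O)c1cc2cnc(Nc3ccc(C(=O)NCCCCN=C=S)cc3)nc2n1C1CCCC1` and compound 3 `CN(C)C(=O)c1cc2cnc(Nc3ccc(C(=O)NCCCCCCN=C=S)cc3)nc2n1C1CCCC1`. In a functional assay on A549 cells (Homo sapiens) for inhibition, read by CCK-8 assay, with a stated time of 72 h, tested at 1 uM (a higher number here means a stronger effect of the compound at the concentration tested, a lower number a weaker effect), compound 1 gives 32.9%, compound 2 gives 30.2% and compound 3 gives 35.8%. Compound 3 thus holds the highest of the three numbers, yet its gaps to both others lie within the scatter: a number 2.9 percentage points higher from compound 1 to compound 3 (within the scatter) and a number 5.6 percentage points higher from compound 2 to compound 3 (within the scatter). The remaining step, a number 2.7 percentage points lower from compound 1 to compound 2 (within the scatter), is also within the scatter, so across these three compounds the chain length shows no effect in this assay.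

Compound 4 `CN(C)C(=O)c1cc2cnc(Nc3ccc(C(=O)NCCCCCCCN=C=S)cc3)nc2n1C1CCCC1` extends the chain once more. The change is a group of 4 heavy atoms (2 carbon, 1 nitrogen, 1 sulfur; no ring) in place of a group of 3 heavy atoms (1 carbon, 1 nitrogen, 1 sulfur; no ring), on a saturated chain carbon, six bonds along the chain from an amide-type nitrogen. All three measured steps are of the same kind, a longer chain in place of a shorter one on the saturated chain carbon, and none of them moved this assay beyond the scatter. For compound 4 the step is therefore expected to be a number 1.8 percentage points lower from compound 3 to compound 4 (within the scatter), none beyond the scatter. Compound 4 is estimated to give 34% in this assay, within a range of 24% to 44%.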

Compound 4, a percentage reported as inhibition, at one concentration (the size of the read-out at that concentration, not a potency): 73.7%
For compound 4 the middle estimate is 39.7 percentage points below the measured one; the measured number lies above the stated range.
By their numbers in this assay, from the lowest: compounds 2, 1 and 3 (each within the scatter of the next); then compound 4.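

In this assay, going by these compounds alone, this position is the first where added chain length moves the read-out: the change on the saturated chain carbon, six bonds along the chain from an amide-type nitrogen, gives a number 37.9 percentage points higher from compound 3 to compound 4 (beyond the scatter). The longest chain also stands clear of the two shortest, with a number 43.5 percentage points higher from compound 2 to compound 4 (beyond the scatter) and a number 40.8 percentage points higher from compound 1 to compound 4 (beyond the scatter), while the three shorter chains remain within the scatter of one another, so the series shows a sharp step at compound 4 rather than a steady gain with each added carbon. The effect of lengthening therefore depends on the chain it starts from, as the same kind of change gives different results at different lengths: the same change on two cores in this assay, a number 2.7 percentage points lower (within the scatter) from compound 1 to compound 2 and a number 37.9 percentage points higher (beyond the scatter) from compound 3 to compound 4, 40.6 percentage points apart, beyond the scatter of two such steps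

As far as these compounds go, whether a longer chain than that of compound 4 would continue the rise, hold it or lose it stays open, as does whether an amine on a chain of this length would keep the higher number. The read-out comes from one concentration in one cell line, so the step gives the size of the effect there and no potency.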